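The source may report more compounds than this note shows. Statements on the series, on what has been measured and on what is new or still open speak of the compounds shown alone.

Compound 1 `CCn1ncnc1-c1ccccc1NCC1=NCCN1` is measured in an in vitro functional assay on cells (Fibroblast) for agonist activity at Alpha-1A adrenergic receptor (Homo sapiens) (a higher number here means that more compound is needed for the effect, a lower number that less compound is needed), where compound 1 gives 1.26 nM. Compound 2 `CC(C)n1ncnc1-c1ccccc1NCC1=NCCN1` differs from it in one place, (methyl in place of hydrogen on a saturated chain carbon bound to an aromatic nitrogen and a saturated chain carbon), and in this assay compound 2 gives 6.31 nM. The step of a 5.0-fold higher number from compound 1 to compound 2 (0.70 log units; beyond the scatter) shows that this single added carbon makes the compound weaker.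

Compound 3 `CCn1nccc1-c1ccccc1NCC1=NCCN1` is built on a different core; the difference between the two cores is not broken down here. In this assay compound 3 gives 63.1 nM, the highest number of the three, with compound 2 standing nearest and compound 1 furthest.

Compound 4 `CCCn1nccc1-c1ccccc1NCC1=NCCN1` is not yet measured. It differs from compound 3 in one place, (methyl in place of hydrogen on a saturated chain carbon, two bonds along the chain from an aromatic nitrogen). Among the compounds with values here, this is the same kind of change as the one from compound 1 to compound 2, but not the same: there the new methyl sat on a saturated chain carbon bound to an aromatic nitrogen and a saturated chain carbon, whereas here it sits on a saturated chain carbon, two bonds along the chain from an aromatic nitrogen. Within the data shown here, only one related example exists, and none on the core of compound 3 itself. A loss is expected, and the expected step is a 2.5-fold higher number from compound 3 to compound 4 (0.40 log units; beyond the scatter), smaller than the earlier one recorded as a 5.0-fold higher number from compound 1 to compound 2 (0.70 log units; beyond the scatter). Compound 4 is accordingly estimated at 160 nM, with a likely range from 50 nM to 500 nM.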

Compound 4, half-maximal effective concentration: 251 nM
Estimate against measurement, compound 4: 1.6-fold (0.20 log units) below, within the range that was stated.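

In this assay the new step is a 4.0-fold higher number from compound 3 to compound 4 (0.60 log units; beyond the scatter) and points the same way as the earlier one, so the added methyl makes the compound weaker on both cores, and the two losses cannot be told apart in size: the same change on two cores in this assay, a 5.0-fold higher number (0.70 log units; beyond the scatter) from compound 1 to compound 2 and a 4.0-fold higher number (0.60 log units; beyond the scatter) from compound 3 to compound 4, 1.3-fold (0.10 log units) apart, within the scatter of two such steps.

For these two pairs, then, the cost of the extra carbon carries over from one core to the other at about the same size. Within the data shown here, this does not show a general rule, since it rests on only two pairs, and the two changes are not identical: on the core of compound 1 the methyl sits on a saturated chain carbon bound to an aromatic nitrogen and a saturated chain carbon, whereas on the core of compound 3 it sits on a saturated chain carbon, two bonds along the chain from an aromatic nitrogen.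

The compounds shown leave open whether a longer chain such as butyl, or a chain ending in a hydroxyl group or an amine, would follow the same course on either core. They also leave open how the branched chain of compound 2 would behave on the core of compound 3.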